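A few compounds are considered here, and "the series" means these few. Any claim that something is new, unique, unknown or untested is made for them only; others in the source may bear on it.

Compound 1 `CC(=O)Nc1ccc2ncc(-c3cnn(C)c3)cc2n1` carries an acetamide on the shared core. In a functional assay on A549 cells (Homo sapiens) for antiproliferative activity, read by MTT assay, with a stated time of 48 h (a higher number here means a weaker inhibitor, a lower number a stronger inhibitor), compound 1 gives only a limit of the assay, > 50000 nM. Compound 2 `Cn1cc(-c2cnc3ccc(NC(=O)c4ccc(F)cc4)nc3c2)cn1` has 4-fluorophenyl in place of methyl on the carbonyl carbon. In this assay compound 2 likewise reaches only a limit of the assay, > 50000 nM. The step that the two limits leave unreadable from compound 1 to compound 2 is therefore not readable, and compound 2 stands nowhere above the floor of the measured values; (the limit of > 50000 nM in this assay, at which 2 of the 2 values shown sit).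

Compound 3 `Cn1cc(-c2cnc3ccc(NC(=O)c4cccnc4)nc3c2)cn1` differs from compound 2 as pyridin-3-yl in place of 4-fluorophenyl on a carbonyl carbon. Among the compounds with values here, the only comparison that touches the same carbonyl carbon, from compound 1 to compound 2, gives no readable size, so no measured step bears on this change. With compound 2 at its limit > 50000 nM, the step that the limit leaves unreadable from compound 2 to compound 3 is expected to stay unreadable. Compound 3 is therefore estimated at 60000 nM, with a range from 20000 nM to 150000 nM, most likely again as a limit.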

Compound 3, half-maximal inhibitory concentration: > 50000 nM
Compound 3 gave a limit, no number; the forecaster's own chance of this, stated with the estimate: 80%; the middle value is on the limit's open side.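

No step can be read among compound 1, compound 2 and compound 3, each of which gives only a limit of the assay: the limit of > 50000 nM in this assay, at which 3 of the 3 values shown sit.

The compounds shown leave open for this assay whether any group on the carbonyl carbon gives a measurable value, and how methyl, 4-fluorophenyl and pyridin-3-yl rank there.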